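This account rests on a few compounds, and the source may have more. Where it says the series, first, only, none or still open, it means among the compounds named here.

For the measured compounds named here, in a functional assay on the whole organism (Hindlimb, strain albino) with Mus musculus as the target, in the maximal electroshock model, with a stated time of 0.5 h (a lower number here means that less compound is needed, a higher number that more compound is needed for the effect), compound 3 (`CC(=O)N1N=C(Nc2nc3ccccc3s2)CC1OC1=CC=C1`) gives 382 umol/kg, the highest of the three numbers so far. Compound 1 (`CC(=O)N1N=C(Nc2nc3ccc([N+](=O)[O-])cc3s2)CC1c1ccc(O)cc1`) gives 162 umol/kg and compound 2 (`CC(=O)N1N=C(Nc2nc3ccc(C)cc3s2)CC1OC1=CC=C1`) gives 160 umol/kg, two values within the scatter of each other.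

Compound 4 (`CC(=O)N1N=C(Nc2nc3ccccc3s2)CC1c1ccc(O)cc1`) comes next, and the change is a group of 7 heavy atoms (6 carbon, 1 oxygen; one six-membered aromatic ring of carbon only) in place of a group of 5 heavy atoms (4 carbon, 1 oxygen; one four-membered non-aromatic ring of carbon only), on a saturated ring carbon. The 4-hydroxyphenyl group enters on a saturated ring carbon of a five-membered non-aromatic ring with 2 nitrogen.

Going by the values given here, the only measured step is a 2.4-fold higher number from compound 2 to compound 3 (0.38 log units; beyond the scatter), which is modest and concerns hydrogen in place of methyl on an aromatic carbon, so it is a guide to size only. Among the compounds with values here, no measured step covers this exchange. Within the data shown here, compound 1 is the only measured compound with the 4-hydroxyphenyl group, and its core differs as well, so its 162 umol/kg gives only a weak pull toward a lower number. A step smaller than the measured one is therefore expected, in that direction. The expected change is a 1.5-fold lower number from compound 3 to compound 4 (0.18 log units; within the scatter). For compound 4 the estimated value is 250 umol/kg, with an expected range of 110 umol/kg to 560 umol/kg.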

Compound 4, dose for half-maximal effect: 249 umol/kg
For compound 4 the middle estimate is 1.0-fold (0.00 log units) above the measured one; the range from low to high includes it.
By their numbers in this assay, from the lowest: compounds 2, 1, 4 and 3 (each within the scatter of the next, the first and the last beyond it).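

In this assay, the 4-hydroxyphenyl group in place of the group of 5 heavy atoms on the saturated ring carbon gives a 1.5-fold lower number from compound 3 to compound 4 (0.19 log units; within the scatter), so this exchange does not separate the two groups at this position. With the 4-hydroxyphenyl group held fixed, removing the nitro group from its aromatic carbon gives a 1.5-fold higher number from compound 1 to compound 4 (0.19 log units; within the scatter), also within the scatter, while hydrogen in place of methyl with the other group at the saturated ring carbon gave a 2.4-fold higher number from compound 2 to compound 3 (0.38 log units; beyond the scatter), beyond it. Nothing measured here speaks to the origin of these steps.

Going by these compounds, it remains open whether a plain phenyl, a 4-methoxyphenyl or a piperidine on the saturated ring carbon would give a step beyond the scatter. On these data alone, the effect of methyl on the aromatic carbon alongside the 4-hydroxyphenyl group also remains open.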